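This account rests on a few compounds, and the source may have more. Where it says the series, first, only, none or still open, it means among the compounds named here.

Series notes. Compound 1 `COC(=O)C[C@H](NC(=O)OC(C)(C)C)C(=O)N(Cc1ccc(F)cc1)C(C)(C)C(=O)NCc1ccccc1` and compound 2 `COC(=O)C[C@H](NC(=O)OC(C)(C)C)C(=O)NC1(C(=O)NCc2ccccc2)CCN(Cc2ccccc2)CC1` share a core. In an ADME assay on MDCK cells (Canis lupus familiaris) for cytotoxicity, read by microscopy, with a stated time of 72 h (on this read-out higher numbers stand for lower toxicity in this test and lower numbers for higher toxicity in this test), compound 1 gives 20000 nM, and in this assay compound 2 gives 100000 nM, the highest of the two numbers, with compound 1 lower by a step beyond the scatter. Compound 3 `COC(=O)C[C@H](NC(=O)OC(C)(C)C)C(=O)N(Cc1ccc([N+](=O)[O-])cc1)C1(C(=O)NCc2ccccc2)CCN(Cc2ccccc2)CC1` differs from compound 2 by 4-nitrobenzyl in place of hydrogen on an amide-type nitrogen. Among the compounds with values here, no measured pair shows this change alone. Within the data shown here, the step from compound 2 to compound 3 is expected to be a 2.0-fold lower number from compound 2 to compound 3 (0.30 log units; within the scatter), a modest move toward lower numbers, given that the only other reading, compound 1 at 20000 nM, lies lower. Compound 3 is thus expected at 50000 nM, within 15000 nM to 150000 nM.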

Compound 3, minimum cytotoxic concentration: 20000 nM
Compound 3: the middle estimate sits 2.5-fold (0.40 log units) above what was measured, and the stated range covers the measured number.
By their numbers in this assay, from the lowest: compounds 1 and 3 (each within the scatter of the next); then compound 2.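

In this assay, within the data shown here, 4-nitrobenzyl in place of hydrogen on the amide-type nitrogen gives a 5.0-fold lower number from compound 2 to compound 3 (0.70 log units; beyond the scatter) and is the first reading of a change at this position. This nitrogen is therefore not silent in this test: with the shared core otherwise unchanged, the substituted compound reads toward higher toxicity in this test. Going by these compounds, whether the step belongs to the benzyl part or to the nitro group stays open, as a plain benzyl, a 4-aminobenzyl or a methyl at this nitrogen would separate the two. Nothing at hand accounts for the step.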